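Notes on the series: a fourth aryl on the ring nitrogen

This account rests on a few compounds, and the source may have more. Where it says the series, first, only, none or still open, it means among the compounds named here.

Three measured compounds share one core and differ only in the aryl group on an amine nitrogen in a ring. Compound 1 `COc1ccc(N2CCN(Cc3csc(N)c3C(=O)c3ccc(Cl)cc3)CC2)cc1` carries a 4-methoxyphenyl there, and in a functional assay on CHO cells with adenosine receptor A1 (Homo sapiens) as the target, read by cAMP accumulation and immunoassay, with a stated time of 6 min, tested at 0.01 uM (on this read-out lower numbers stand for a stronger effect and higher numbers for a weaker effect at the one concentration tested), compound 1 gives -1.2%. Compound 2 `Nc1scc(CN2CCN(c3ccc(OC(F)(F)F)cc3)CC2)c1C(=O)c1ccc(Cl)cc1` carries a 4-(trifluoromethoxy)phenyl, and in this assay compound 2 gives 0%. Compound 3 `Nc1scc(CN2CCN(c3ccc(F)cc3F)CC2)c1C(=O)c1ccc(Cl)cc1` carries a 2,4-difluorophenyl, and in this assay compound 3 gives 0%. Compound 3 stands level with compound 2 at the digits read, the two together holding the highest of the three numbers; the steps of a number 1.2 percentage points higher from compound 1 to compound 3 (within the scatter) and no change at the digits printed from compound 2 to compound 3 (within the scatter) are both within the scatter, as is a number 1.2 percentage points higher from compound 1 to compound 2 (within the scatter). None of the three aryl groups moves the read-out beyond the scatter at the one concentration tested.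

Compound 4 `Nc1scc(CN2CCN(c3cccc(F)c3F)CC2)c1C(=O)c1ccc(Cl)cc1` is not yet measured. It differs from compound 3 by 2,3-difluorophenyl in place of 2,4-difluorophenyl on an amine nitrogen in a ring, the same position at which the measured compounds were varied. Because a number 1.2 percentage points higher from compound 1 to compound 3 (within the scatter) and no change at the digits printed from compound 2 to compound 3 (within the scatter) both stayed within the scatter, the expected step of no change at the digits printed from compound 3 to compound 4 (within the scatter) is taken to lie within the scatter as well, with no direction favoured. Compound 4 is therefore estimated to give 0% in this assay, within a range from -8% to 8%.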

Compound 4, a percentage reported as activity, at one concentration (the size of the read-out at that concentration, not a potency): -13%
The estimate for compound 4 lay 13 percentage points above the measured number; measured number outside the range, below it.
By their numbers in this assay, from the lowest: compound 4; then compounds 1, 2 and 3 (each within the scatter of the next).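

In this assay, the exchange of 2,4-difluorophenyl for 2,3-difluorophenyl gives a number 13 percentage points lower from compound 3 to compound 4 (beyond the scatter), so this position responds beyond the scatter to a change that leaves the atoms of the group the same and alters only how they are joined. The other two steps, a number 13 percentage points lower from compound 2 to compound 4 (beyond the scatter) and a number 11.8 percentage points lower from compound 1 to compound 4 (beyond the scatter), set the 2,3-difluorophenyl group apart from 4-(trifluoromethoxy)phenyl and 4-methoxyphenyl as well, so the agreement among compounds 1, 2 and 3 did not mean that the read-out is insensitive to the aryl group on this ring nitrogen. Nothing on hand accounts for the difference between the two difluorophenyl groups.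

From the compounds shown here alone, whether a 2,3-dichlorophenyl or 2,3-dimethylphenyl group on the same ring nitrogen would read with compound 4 or with compounds 1, 2 and 3 remains open, and so does the reading for an unsubstituted phenyl. Since this assay reports the size of the effect at one concentration, the shown values also leave open how far compound 4 differs from compound 3 in potency.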